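Trimming the Alkyne Chain to a Terminal Ethynyl

The source may report more compounds than this note shows. Statements on the series, on what has been measured and on what is new or still open speak of the compounds shown alone.

Compound 1 `CN1CCC[C@H]1COc1cccnc1`: 7.7 nM
Compound 2 `CN1CCC[C@H]1COc1cncc(C#CC(C)(C)O)c1`: 23 nM
Compound 3 `CCCCC#Cc1cncc(OC[C@@H]2CCCN2C)c1`: 21 nM

In an assay on a protein complex for binding affinity to Neuronal acetylcholine receptor; alpha3/beta2 (Homo sapiens) (on this read-out lower numbers stand for stronger inhibition and higher numbers for weaker inhibition), compound 3 gives 21 nM, the second highest of the three numbers; its nearest neighbour is compound 2 (a 1.1-fold lower number from compound 2 to compound 3 (0.04 log units; within the scatter)), its furthest compound 1 (a 2.7-fold higher number from compound 1 to compound 3 (0.44 log units; beyond the scatter)). Compound 4 `C#Cc1cncc(OC[C@@H]2CCCN2C)c1` differs from compound 3 by hydrogen in place of butyl on a triple-bonded carbon. Among the measured compounds shown here, two measured steps bear on this. Adding a hex-1-yn-1-yl to the shared core gave a 2.7-fold higher number from compound 1 to compound 3 (0.44 log units; beyond the scatter), and adding a 3-hydroxy-3-methylbut-1-yn-1-yl gave a 3.0-fold higher number from compound 1 to compound 2 (0.48 log units; beyond the scatter); swapping the chain end, a 1.1-fold lower number from compound 2 to compound 3 (0.04 log units; within the scatter), changed little. The terminal ethynyl of compound 4 keeps the triple bond but removes the four-carbon chain, so a number between that of compound 1 and compound 3 is expected, a small downward step at most. Compound 4 is therefore estimated at 13 nM (range 5 nM to 35 nM), which would mean a 1.6-fold lower number from compound 3 to compound 4 (0.21 log units; within the scatter).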

Compound 4, inhibition constant: 8.2 nM
Beside the measured number, compound 4's estimate is 1.6-fold (0.20 log units) above it, within the range that was stated.
By their numbers in this assay, from the lowest: compounds 1 and 4 (each within the scatter of the next); then compounds 3 and 2 (each within the scatter of the next).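

In this assay, the full butyl group proves dispensable on the triple-bonded carbon: hydrogen in its place gives a lower number (a 2.6-fold lower number from compound 3 to compound 4 (0.41 log units; beyond the scatter)), and hydrogen in place of 1-hydroxy-1-methylethyl does the same (a 2.8-fold lower number from compound 2 to compound 4 (0.45 log units; beyond the scatter)). The triple bond alone leaves the number within the scatter of the unsubstituted core (a 1.1-fold higher number from compound 1 to compound 4 (0.03 log units; within the scatter)), so the higher numbers of compound 2 and compound 3 go with the groups carried on the triple-bonded carbon rather than with the ethynyl unit itself. No measurement shown explains why these groups raise the number.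

The compounds shown leave open whether a single methyl on the triple-bonded carbon would already raise the number. They also leave open whether an amine or a carboxylic acid at the chain end would track with butyl and 1-hydroxy-1-methylethyl.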